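The source may report more compounds than this note shows. Statements on the series, on what has been measured and on what is new or still open speak of the compounds shown alone.

Measured so far in an ADME assay on C8166 cells (Homo sapiens) for cytotoxicity, read by MTT assay; on this read-out higher numbers stand for lower toxicity in this test and lower numbers for higher toxicity in this test:
- compound 1, `Cc1cc(S(N)(=O)=O)ccc1NC(=O)COc1ccc(Cl)cc1C(O)c1ccccc1Cl`: 32000 nM
- compound 2, `Cc1cc(S(N)(=O)=O)ccc1NC(=O)COc1ccc(Cl)cc1C(O)c1cccc(F)c1`: 37600 nM
- compound 3, `Cc1ccc(C)c(C(O)c2cc(Cl)ccc2OCC(=O)Nc2ccc(S(N)(=O)=O)cc2C)c1`: 35500 nM

All three share one core and differ only in the aryl group on a saturated chain carbon bound to an aromatic carbon and an oxygen on a saturated carbon. Compound 2 carries the 3-fluorophenyl there; its steps to the other two are a 1.2-fold higher number from compound 1 to compound 2 (0.07 log units; within the scatter) and a 1.1-fold lower number from compound 2 to compound 3 (0.02 log units; within the scatter), both within the scatter, so the three numbers are indistinguishable on this read-out. The third step, a 1.1-fold higher number from compound 1 to compound 3 (0.05 log units; within the scatter), is likewise within the scatter.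

Compound 4, `Cc1cc(S(N)(=O)=O)ccc1NC(=O)COc1ccc(Cl)cc1C(O)c1cc(Cl)cc(C#N)c1`, is the next member to be measured in this assay. Its difference from compound 2 is 3-chloro-5-cyanophenyl in place of 3-fluorophenyl on a saturated chain carbon bound to an aromatic carbon and an oxygen on a saturated carbon.

Every measured step in this series is a swap of the aryl group at the same place, and none of them moved the number beyond the scatter. Going by the values given here, no step shows the 3-chloro-5-cyanophenyl group, so the nitrile has no precedent here; the expectation rests on the three aryl swaps alone. The expected step from compound 2 to compound 4 is therefore a 1.0-fold lower number from compound 2 to compound 4 (0.02 log units; within the scatter), with no direction claimed beyond the scatter. Compound 4 is estimated at 36000 nM in this assay, within 18000 nM to 72000 nM.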

Compound 4, half-maximal cytotoxic concentration: 31600 nM
The estimate for compound 4 lay 1.1-fold (0.06 log units) above the measured number, within the range that was stated.
By their numbers in this assay, from the lowest: compounds 4, 1, 3 and 2 (each within the scatter of the next).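

In this assay, the aryl swaps at the place on a saturated chain carbon bound to an aromatic carbon and an oxygen on a saturated carbon now extend to a group carrying a nitrile, and the number still stays within the scatter: a 1.2-fold lower number from compound 2 to compound 4 (0.08 log units; within the scatter), a 1.1-fold lower number from compound 3 to compound 4 (0.05 log units; within the scatter) and a 1.0-fold lower number from compound 1 to compound 4 (0.01 log units; within the scatter). Going by these compounds alone, the 3-chloro-5-cyanophenyl group, the only aryl group with a triple bond, therefore gives a result that cannot be told apart from those of the 3-fluorophenyl, 2-chlorophenyl and 2,5-dimethylphenyl groups, so all four compounds are level on this read-out. Nothing available bears on why the number stays this flat.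

Still open, on these data alone, is whether an aryl group carrying an amine or a carboxylic acid, or a longer chain in place of the aryl ring, would move the number beyond the scatter. As far as these compounds go, all four compounds also keep the hydroxyl on that carbon and the rest of the shared core, so the effect of a change elsewhere in this assay remains unknown.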